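A few compounds are considered here, and "the series" means these few. Any claim that something is new, unique, unknown or untested is made for them only; others in the source may bear on it.

Measured so far in a functional assay, tested at 100 ug/mL; a lower number here means a stronger effect, a higher number a weaker effect of the compound at the concentration tested:
compound 1 `CCOC(=O)C1=C(C)N(c2ccccc2)C=CC1c1ccccc1` gives -13.8%
compound 2 `COC(=O)C1=C(C)N(c2ccccc2)C=CC1c1ccccc1` gives -26.9%
compound 3 `COC(=O)C1=C(C)N(c2ccccc2)C=C(C)C1c1ccccc1` gives -14.1%

Compound 2 stands lowest of the three numbers in this assay; the gaps are the step of a number 12.8 percentage points higher from compound 2 to compound 3 (beyond the scatter) and the step of a number 13.1 percentage points lower from compound 1 to compound 2 (beyond the scatter), both beyond the scatter and both modest.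

Compound 4 `COC(=O)C1=C(C)N(c2ccccc2)C=CC1c1ccc(OC)cc1` differs from compound 2 by methoxy in place of hydrogen on an aromatic carbon. Neither measured step touches the aromatic ring: one concerns the saturated chain carbon bound to an oxygen, the other a double-bonded ring carbon of the shared core. Among the compounds with values here, no measured step therefore bears directly on this change. Since both earlier changes gave only modest steps, a step within or near the scatter, with no established direction, is expected here. Compound 4 is estimated at -25% in this assay, range -42% to -8%. The expected step is a number 1.9 percentage points higher from compound 2 to compound 4 (within the scatter).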

Compound 4, a percentage reported as activity, at one concentration (the size of the read-out at that concentration, not a potency): -18.3%
Estimate against measurement, compound 4: 6.7 percentage points below; the measured number falls inside the stated range.
By their numbers in this assay, from the lowest: compounds 2, 4, 3 and 1 (each within the scatter of the next, the first and the last beyond it).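

Phenyl to 4-methoxyphenyl is the first change on an aromatic ring in this series, and in this assay it gives a number 8.6 percentage points higher from compound 2 to compound 4 (within the scatter). Unlike the two earlier single changes, which lie beyond the scatter, this one leaves methoxy indistinguishable from hydrogen at this place. Nothing on hand gives a reason for this result.

On these data alone, whether an amine, a carboxylic acid or a chlorine atom at this same place would shift the read-out beyond the scatter remains open. Also open, as far as these compounds go, is whether methoxy on the other aromatic ring would behave alike.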